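The compounds below may be only part of what the source reports. "The series", "measured", "known", "first", "only" and "open" are said of these compounds alone.

In a functional assay on MCF7 cells (Homo sapiens) for inhibition, read by radiometric assay and XTT assay (on this read-out higher numbers stand for weaker inhibition and lower numbers for stronger inhibition), compound 1 (`CCCCCC[C@@]1(C)SC(=O)C=C1OC`) gives 9.4 ug/mL and compound 2 (`CCCCCCCC[C@@]1(C)SC(=O)C=C1OC`) gives 16.4 ug/mL as values within the scatter of each other, while compound 3 (`CCCCCCCC[C@@]1(C)SC(=O)C=C1OCC(=O)O`) gives 50.3 ug/mL as the highest number of the three. Compound 4 (`CCCCCC[C@@]1(C)SC(=O)C=C1OCC(=O)NCCCBr`) carries this change from compound 1: (3-bromopropyl)carbamoyl in place of hydrogen on a saturated chain carbon bound to an oxygen on an unsaturated carbon with the rest of the structure unchanged. The closest measured change at that place, with a carboxy group, is a 3.1-fold higher number from compound 2 to compound 3 (0.49 log units; beyond the scatter) and counts as modest, whereas a 1.7-fold higher number from compound 1 to compound 2 (0.24 log units; within the scatter) concerns only the chain. For the measured compounds named here, no measured compound carries the new group, so a modest step towards a higher number is expected in this assay on the evidence of a 3.1-fold higher number from compound 2 to compound 3 (0.49 log units; beyond the scatter) alone. The expected change is a 2.7-fold higher number from compound 1 to compound 4 (0.42 log units; beyond the scatter) as a rough estimate. For compound 4 the estimated value is 25 ug/mL within an expected range of 8 ug/mL to 70 ug/mL for now.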

Compound 4, half-maximal inhibitory concentration: 21 ug/mL
For compound 4 the middle estimate is 1.2-fold (0.08 log units) above the measured one; the range from low to high includes it.
By their numbers in this assay, from the lowest: compounds 1, 2 and 4 (each within the scatter of the next, the first and the last beyond it); then compound 3.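

At this place on a saturated chain carbon bound to an oxygen on an unsaturated carbon, this assay shows a 2.2-fold higher number from compound 1 to compound 4 (0.35 log units; beyond the scatter) on the chain of compound 1 with (3-bromopropyl)carbamoyl in place of hydrogen. The earlier compounds shown here showed a change here only with carboxy on the longer chain of compound 2, and this second, uncharged group also moves the number upward, so neither substituted compound goes against that direction. Nothing measured bears on the reason for this step.

Open, as far as these compounds go, is how a plain propylcarbamoyl group without the bromine, or an amine at the end of that chain, would read. Also open, from the compounds shown here alone, is how a carboxylic acid on the chain of compound 1 would read.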